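Sulfonamide-amide series: fluoro for methyl on the sulfonyl aryl

A few compounds are considered here, and "the series" means these few. Any claim that something is new, unique, unknown or untested is made for them only; others in the source may bear on it.

Compound 1 `COc1ccccc1C(=O)NCc1ccc(CNS(=O)(=O)c2ccccc2C)cc1` gives 1000 nM in an assay on MDA-MB-231 cells for displacement of a labelled ligand from C-X-C chemokine receptor type 4 (Homo sapiens), read by fluorescence and microscopy, with stated times of 10 min and 30 min; on this read-out higher numbers stand for an effect only at larger amounts of compound and lower numbers for an effect already at smaller amounts.
Compound 2 `Cc1ccccc1C(=O)NCc1ccc(CNS(=O)(=O)c2ccc(Cl)cc2)cc1` gives 1 nM in this assay.
Compound 3 `Cc1ccccc1S(=O)(=O)NCc1ccc(CNC(=O)c2cccnc2)cc1` gives 1000 nM in this assay.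

Compound 1 stands level with compound 3 at the digits shown, the two together giving the highest numbers of the three. For the measured compounds named here, the one step between singly differing compounds, no change at the digits printed from compound 1 to compound 3 (within the scatter), alters only the group on the carbonyl carbon and leaves the read-out unchanged. Compound 2 sits far lower, but compound 2 differs from compound 1 in more than one place, so the two values alone are known and no single change can be read off them.

Compound 4 `COc1ccccc1C(=O)NCc1ccc(CNS(=O)(=O)c2ccccc2F)cc1` has not yet been measured. Against compound 1 the difference is fluoro in place of methyl on an aromatic carbon. Going by the values given here, no measured step touches the sulfonyl aryl: the only step in hand concerns the carbonyl side and shows no change within the scatter, and nothing in the data tells how a single small exchange on the sulfonyl aryl moves the number. The expectation for compound 4 in this assay is therefore a step of no change at the digits printed from compound 1 to compound 4 (within the scatter), that is no change beyond the scatter, with the estimate for compound 4 set at 1000 nM and a range from 300 nM to 3000 nM.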

Compound 4, effective concentration (reported as EC, without a stated level of effect): 1 nM
Compound 4: middle estimate off by 1000-fold (3.00 log units), on the high side, outside the stated range (below it).
By their numbers in this assay, from the lowest: compounds 2 and 4 (each within the scatter of the next); then compounds 1 and 3 (each within the scatter of the next).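

The exchange of 2-methylphenyl for 2-fluorophenyl on the sulfonyl side gives a 1000-fold lower number from compound 1 to compound 4 (3.00 log units; beyond the scatter) in this assay, so this aromatic carbon, ortho to a large group, is highly sensitive to a single-atom exchange, even though the two groups match in heavy-atom count, hydrogen-bond donors and acceptors, and net charge. The only earlier single-place step, on the carbonyl side, gave no change at the digits printed from compound 1 to compound 3 (within the scatter), which makes the sulfonyl aryl the one place shown where a single exchange moves the number, although each side is represented by just one step. Nothing measured on these compounds bears on why a change this small has so large an effect.

As far as these compounds go, it remains open whether the step belongs to fluoro itself or to the departure of methyl, a question that chloro, methoxy or plain hydrogen on the same carbon would help to settle. From the compounds shown here alone, it is also open whether the exchange carries the same weight with pyridin-3-yl in place of 2-methoxyphenyl on the carbonyl carbon, as in compound 3.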